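This account rests on a few compounds, and the source may have more. Where it says the series, first, only, none or still open, it means among the compounds named here.

Compound 1 `CC(C)(C)OC(=O)n1cc(-c2cccc(NC(=O)c3ccc[nH]3)c2)nc1N` and compound 2 `CC(C)(C)OC(=O)n1cc(-c2cccc(NC(=O)c3c[nH]c4ccccc34)c2)nc1N` share a core and differ only in the ring joined to the amide carbonyl. In an assay on isolated protein for inhibition of sodium channel protein type 3 subunit alpha (Homo sapiens), read by electrophysiology, with a stated time of 4 min (on this read-out lower numbers stand for stronger inhibition and higher numbers for weaker inhibition), compound 1 gives 25000 nM, and compound 2 gives 27000 nM. The step from the first to the second, a 1.1-fold higher number from compound 1 to compound 2 (0.03 log units; within the scatter), shows that swapping one aromatic ring for a larger fused one at that position left the read-out essentially unchanged. Going by the values given here, compound 2 thus holds the higher of the two numbers measured so far, though its gap to compound 1 lies within the usual scatter.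

Compound 3 `CC(C)(C)OC(=O)n1cc(-c2cccc(NC(=O)[C@H]3CCCN3)c2)nc1N` carries the change (pyrrolidin-2-yl in place of 1H-indol-3-yl on a carbonyl carbon), so the carbonyl now bears a small saturated ring instead of the aromatic fused one. Among the compounds with values here, the only measured step that bears on this position, from compound 1 to compound 2, is small, and no measured compound shows a non-aromatic ring here. Against that background the expected step of a 1.3-fold higher number from compound 2 to compound 3 (0.11 log units; within the scatter) is modest, leaning toward a weaker outcome. Compound 3 is therefore estimated at 35000 nM, with a plausible range from 10000 nM to 120000 nM.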

Compound 3, half-maximal inhibitory concentration: > 30000 nM
Compound 3 was reported as a limit; the forecaster's own chance of this, stated with the estimate: 30%; the middle value does not contradict the limit.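

Compound 3 is reported only as a limit in this assay, not as an exact number: the limit of > 30000 nM in this assay, at which 1 of the 3 values shown sits.

Putting pyrrolidin-2-yl in place of 1H-indol-3-yl on the carbonyl carbon gives an at least 1.1-fold higher number from compound 2 to compound 3 (0.04 log units; that floor lies within the scatter), and putting it in place of 1H-pyrrol-2-yl gives an at least 1.2-fold higher number from compound 1 to compound 3 (0.07 log units; that floor lies within the scatter). These steps add the first non-aromatic ring at this position to the picture: it gives no sign of stronger inhibition, but a floor within the scatter cannot tell whether it truly weakens inhibition relative to the two aromatic rings, or by how much.

The compounds shown leave open whether a group of a different kind on this carbonyl carbon, such as an open-chain amine, a carboxylic acid or a longer carbon chain, would move the number beyond the scatter. They also leave open whether the defined stereocentre of pyrrolidin-2-yl matters, as only one mirror-image form appears here, and whether a change elsewhere on the shared core would have a larger effect.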